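The source may hold more compounds than are shown below. What is called first, only, known or untested is meant among the compounds shown, and "the series" means these compounds.

Working notes on the series. In an ADME assay on TZM cells (Homo sapiens) for cytotoxicity, with a stated time of 1 days (on this read-out lower numbers stand for higher toxicity in this test and higher numbers for lower toxicity in this test), compound 1 (`CCNC(=O)c1cc(N)c(Nc2ccc(C#N)cc2)cc1Oc1c(C)cc(CCC#N)cc1C`) gives 105000 nM and compound 2 (`Cc1cc(CCC#N)cc(C)c1Oc1cc(Nc2ccc(C#N)cc2)c(N)cc1C(=O)NC(C)C`) gives 184000 nM, with a 1.8-fold higher number from compound 1 to compound 2 (0.24 log units; within the scatter). Compound 3 (`Cc1cc(CCC#N)cc(C)c1Oc1cc(Nc2ccc(C#N)cc2)c(N)cc1CN(C)C`) gives 23800 nM, the lowest number of the three.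

Compound 4 (`CC(=O)OCc1cc(N)c(Nc2ccc(C#N)cc2)cc1Oc1c(C)cc(CCC#N)cc1C`) is the next case: acetoxy in place of dimethylamino on a saturated chain carbon bound to an aromatic carbon. This places acetoxy in place of dimethylamino on a saturated chain carbon bound to an aromatic carbon. Within the data shown here, no measured compound carries acetoxy, so the evidence is indirect. Among the measured compounds shown here, the steps that bear on it are the two that replace an amide-bearing group with (dimethylamino)methyl: a 4.4-fold lower number from compound 1 to compound 3 (0.64 log units; beyond the scatter) and a 7.7-fold lower number from compound 2 to compound 3 (0.89 log units; beyond the scatter). Both are modest and both end at compound 3, so losing the dimethylamino group is expected to reverse part of that drop, with compound 1 and compound 2 as the rough upper reference.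

A modest rise in this assay is expected, and the estimated step is a 2.9-fold higher number from compound 3 to compound 4 (0.47 log units; beyond the scatter). The estimate for compound 4 is 70000 nM, with an expected range of 28000 nM to 180000 nM.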

Compound 4, half-maximal cytotoxic concentration: 44800 nM
The estimate for compound 4 lay 1.6-fold (0.19 log units) above the measured number; low and high end bracket the measured number.
By their numbers in this assay, from the lowest: compounds 3 and 4 (each within the scatter of the next); then compounds 1 and 2 (each within the scatter of the next).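

In this assay, acetoxy in place of dimethylamino on a saturated chain carbon bound to an aromatic carbon gives a 1.9-fold higher number from compound 3 to compound 4 (0.27 log units; within the scatter), so this change does not separate the two groups here. The amides keep their distance from the new ester as well, with a 4.1-fold lower number from compound 2 to compound 4 (0.61 log units; beyond the scatter) and a 2.3-fold lower number from compound 1 to compound 4 (0.37 log units; beyond the scatter), which shows that the lower numbers seen earlier with (dimethylamino)methyl are not confined to that group among these compounds. No measurement at hand offers an explanation for these differences.

Going by these compounds, whether a hydroxymethyl or a carboxylic acid on the same aromatic carbon would fall with compound 3 and compound 4 or with the amides remains open. On these data alone, it also remains open whether the same ordering would hold on a core other than the one shared here.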